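Working notes: from compound 2 to compound 3

This account rests on a few compounds, and the source may have more. Where it says the series, first, only, none or still open, it means among the compounds named here.

In a physicochemical assay, in phosphate buffer, with a stated time of 3 h, at 37 degrees C, at pH 1.2 (on this read-out higher numbers stand for a more stable compound and lower numbers for a less stable compound), compound 1 (`CC(C)(C)c1cc2c(N/N=C/c3nccs3)ncnc2s1`) gives 79% and compound 2 (`CC(N)c1csc(/C=N/Nc2ncnc3sc(C(C)(C)C)cc23)n1`) gives 81%. For the measured compounds named here, compound 2 therefore stands level with compound 1, its only measured neighbour: the step is a number 2 percentage points higher from compound 1 to compound 2 (within the scatter), with 1-aminoethyl in place of hydrogen on an aromatic carbon.

Compound 3 (`CC(N)c1csc(/C=N/Nc2ncnc3sc(C(C)C(C)C)cc23)n1`) keeps the 1-aminoethyl of compound 2 and carries 1,2-dimethylpropyl in place of tert-butyl on an aromatic carbon, next to the ring sulfur (1,2-dimethylpropyl in place of tert-butyl on an aromatic carbon). Going by the values given here, no measured step covers a change of this alkyl group. Among the compounds with values here, the one step available, a number 2 percentage points higher from compound 1 to compound 2 (within the scatter), concerns a different group and stays within the scatter, so it offers only a weak guide and no direction. On that limited evidence, no shift beyond the scatter is expected in this assay, and compound 2 at 81% serves as the anchor. The expected step is a number 1 percentage points lower from compound 2 to compound 3 (within the scatter), with no direction favoured. For compound 3 the estimate is 80%, with an expected range of 68% to 91%.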

Compound 3, percent of the compound remaining: 83%
Beside the measured number, compound 3's estimate is 3 percentage points below it; the measured number falls inside the stated range.
By their numbers in this assay, from the lowest: compounds 1, 2 and 3 (each within the scatter of the next).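

In this assay, the position on the aromatic carbon next to the ring sulfur now has its first measured step: a number 2 percentage points higher from compound 2 to compound 3 (within the scatter), with 1,2-dimethylpropyl in place of tert-butyl. With the 1-aminoethyl group held constant, exchanging the 4-carbon tert-butyl for the 5-carbon 1,2-dimethylpropyl therefore leaves the percent remaining within the scatter, so this one pair shows that the alkyl group at this position can be changed in this way without a readable effect on this measure of stability, just as the earlier step showed for adding 1-aminoethyl at the other site. No measurement is available that explains the numbers in this pair.

From the compounds shown here alone, it remains open whether a longer chain such as n-hexyl, or an amine or a carboxylic acid, in place of the alkyl group on this aromatic carbon would produce a step beyond the scatter. For the compounds shown here, it also remains open whether 1,2-dimethylpropyl would read the same with hydrogen in place of the 1-aminoethyl group, since no step so far isolates that combination.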